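Swapping the aryl group on the piperazine nitrogen

The source may report more compounds than this note shows. Statements on the series, on what has been measured and on what is new or still open speak of the compounds shown alone.

Measured so far:
compound 1, `Cc1ccc(C)c(N2CCN(C(=O)c3oc(C)nc3-c3ccccc3F)CC2)c1`: 319 nM
compound 2, `Cc1ccc(N2CCN(C(=O)c3oc(C)nc3-c3ccccc3)CC2)c(C)c1`: 101 nM
compound 3, `COc1cc(OC)cc(N2CCN(C(=O)c3oc(C)nc3-c3cccc(F)c3)CC2)c1`: 28.2 nM

In a functional assay on HL-60 cells (Homo sapiens) for inhibition, read by MTT assay, with a stated time of 72 h (on this read-out higher numbers stand for weaker inhibition and lower numbers for stronger inhibition), compound 2 gives 101 nM and stands second highest of the three numbers, with compound 1 above it and compound 3 below it, both gaps beyond the scatter. Compound 4, `Cc1nc(-c2ccccc2)c(C(=O)N2CCN(c3cccc(C#N)c3)CC2)o1`, has not yet been measured. It differs from compound 2 in one place: 3-cyanophenyl in place of 2,4-dimethylphenyl on an amine nitrogen in a ring. Among the compounds with values here, no pair of measured compounds shares exactly this kind of change, so the data give no direct guide to its effect. The step of a 1.3-fold higher number from compound 2 to compound 4 (0.11 log units; within the scatter) is expected to stay within the scatter, with no clear direction. For compound 4 the estimate is 130 nM in this assay, likely between 35 nM and 500 nM.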

Compound 4, half-maximal inhibitory concentration: 39.6 nM
The estimate for compound 4 lay 3.3-fold (0.52 log units) above the measured number, and the stated range covers the measured number.
By their numbers in this assay, from the lowest: compounds 3 and 4 (each within the scatter of the next); then compound 2; then compound 1.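

In this assay, 3-cyanophenyl in place of 2,4-dimethylphenyl on the amine nitrogen in the ring gives a 2.6-fold lower number from compound 2 to compound 4 (0.41 log units; beyond the scatter), so the aryl group at this position does affect the result. The entering group has a hydrogen-bond acceptor and the leaving group has none, but no measurement ties the change in potency to that difference or to anything else.

The compounds shown cannot separate the loss of the two methyl groups from the gain of the nitrile. An unsubstituted phenyl, or a phenyl bearing a carboxylic acid or an amine, would help to tell these apart.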